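Aryl urea substituent: methyl to chloro on compound 3

This account rests on a few compounds, and the source may have more. Where it says the series, first, only, none or still open, it means among the compounds named here.

In a functional assay (aorta) with Rattus norvegicus as the target (on this read-out lower numbers stand for an effect already at smaller amounts and higher numbers for an effect only at larger amounts of compound), compound 3 `Cc1ccc(NC(=O)NC2CC(C)(C)Oc3ccc(Br)cc32)cc1` gives > 30000 nM, a limit of the assay rather than a number. Compound 2 `Cc1ccc(NC(=O)NC2CC(C)(C)Oc3ccc(Cl)cc32)cc1` likewise gives > 30000 nM, also a limit. Compound 1 `CC1(C)CC(NC(=O)Nc2ccccc2)c2cc(Br)ccc2O1` gives 2300 nM. Methyl in place of hydrogen on an aromatic carbon gave an at least 13-fold higher number from compound 1 to compound 3 (1.11 log units; beyond the scatter). Bromo in place of chloro gave a step that the two limits leave unreadable from compound 2 to compound 3, since both values sit at the limit of > 30000 nM in this assay, at which 2 of the 3 values shown sit. Compound 4 `CC1(C)CC(NC(=O)Nc2ccc(Cl)cc2)c2cc(Br)ccc2O1` differs from compound 3 by chloro in place of methyl on an aromatic carbon. Among the compounds with values here, no measured step sets chloro against methyl; the only bearing step is an at least 13-fold higher number from compound 1 to compound 3 (1.11 log units; beyond the scatter), which places the unsubstituted phenyl of compound 1 inside the measurable range. Compound 4 is therefore estimated at 10000 nM, between 2500 nM and 30000 nM. That expectation means a step of an at least 3.0-fold lower number from compound 3 to compound 4 (0.47 log units; beyond the scatter) toward lower numbers, with a real chance of another limit.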

Compound 4, half-maximal effective concentration: > 300000 nM
Compound 4 ended at the assay's limit; the forecaster's own chance of this, stated with the estimate: 40%; at least 30-fold (1.47 log units) between middle value and limit.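

In this assay compound 4 gives > 300000 nM, a limit of the assay and not a number. Chloro in place of hydrogen gives an at least 130-fold higher number from compound 1 to compound 4 (2.11 log units; beyond the scatter), so with methyl in compound 3, a second group on this aromatic carbon, para to a large group, has now left the measurable range, and only the unsubstituted phenyl of compound 1 keeps a readable value. The steps between limits cannot be read, so methyl and chloro stay unordered here.

Open, going by these compounds, is whether any group at this position keeps a readable value, for instance an amine or a carboxylic acid.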